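The source may report more compounds than this note shows. Statements on the series, on what has been measured and on what is new or still open speak of the compounds shown alone.

Three compounds have been measured in an ADME assay on MDCK-MDR1 cells (Canis lupus familiaris) for permeability, in the apical to basolateral direction, with a stated time of 180 min; a higher number here means that the compound crosses the layer faster, a lower number that the compound crosses the layer more slowly:

Compound 1 `CN(C)CCC(=O)Nc1ccc([C@H]2[C@@H](F)[C@@H](F)C[C@@H](F)[C@H]2F)cc1` gives 3.7 10^-6 cm/s
Compound 2 `CC(=O)N1CC(C(=O)Nc2ccc(C3CCCCC3)cc2)C1` gives 18.7 10^-6 cm/s
Compound 3 `O=C(Cn1ccnc1)Nc1ccc(C2CCCCC2)cc1` gives 11.1 10^-6 cm/s

Among these three, compound 3 has the second highest number. Its nearest neighbour is compound 2: the change was a 1.7-fold lower number from compound 2 to compound 3 (0.23 log units; within the scatter), so the two cannot be told apart. Compound 1, at 3.7 10^-6 cm/s, lies well below compound 3, and this gap is larger than the scatter.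

The next compound, compound 4 `COCCC(=O)Nc1ccc(C2CCCCC2)cc1`, has not been measured in this assay. It is made from compound 3 by one change: methoxymethyl in place of 1H-imidazol-1-yl on a saturated chain carbon bound to a carbonyl carbon. Among the compounds with values here, none of the measured steps changes this part of the molecule in the same way; the only step available, from compound 2 to compound 3, swapped a different group at the same chain position and stayed within the scatter. Within the data shown here, with no step in the data pointing clearly up or down, the expected step is a 1.2-fold higher number from compound 3 to compound 4 (0.07 log units; within the scatter), that is, no change beyond the scatter. Compound 4 is therefore expected to give about 13 10^-6 cm/s, with a range from 6 10^-6 cm/s to 26 10^-6 cm/s.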

Compound 4, apparent permeability: 22.2 10^-6 cm/s
Compound 4: the middle estimate sits 1.7-fold (0.23 log units) below what was measured; the measured number falls inside the stated range.
By their numbers in this assay, from the lowest: compound 1; then compounds 3, 2 and 4 (each within the scatter of the next).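

At the saturated chain carbon bound to a carbonyl carbon, replacing the 1H-imidazol-1-yl ring with the open-chain methoxymethyl group gives a 2.0-fold higher number from compound 3 to compound 4 (0.30 log units; within the scatter) in this assay, so removing that ring makes no change that can be told from the scatter. Comparing 2-methoxyethyl with 1-acetylazetidin-3-yl on the carbonyl carbon gives a 1.2-fold higher number from compound 2 to compound 4 (0.07 log units; within the scatter), so the three side chains on this shared core, with and without a ring, cannot be told apart in this measurement. Nothing available here explains why such different groups give such similar numbers.

Going by these compounds, it remains open whether this tolerance would extend to a carboxylic acid or a primary amine at this position. Compound 1, at 3.7 10^-6 cm/s, differs from these compounds in two places, so its number cannot be tied to either difference alone.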